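A sulfonyl swap on a chloro-styryl ketone scaffold

A few compounds are considered here, and "the series" means these few. Any claim that something is new, unique, unknown or untested is made for them only; others in the source may bear on it.

Compound 3 `Cc1ccc(C)c(/C=C(\C(=O)c2ccc(Cl)cc2)S(=O)(=O)Cc2ccc(Cl)cc2)c1` gives 10000 nM in a functional assay on DU-145 cells (Homo sapiens) for inhibition, read by trypan blue exclusion, with a stated time of 96 h (a lower number here means a stronger inhibitor of growth, a higher number a weaker inhibitor of growth), level with compound 1 `Cc1cc(C)cc(/C=C(\C(=O)c2ccc(Cl)cc2)S(=O)(=O)c2ccc(Br)cc2)c1`, which gives 10000 nM; together they stand highest of the three measured compounds. Going by the values given here, compound 2 `Cc1ccc(/C=C(\C(=O)c2ccc(Cl)cc2)S(=O)(=O)Cc2ccc(Cl)cc2)s1` gives 1000 nM, and the single step of a 10-fold higher number from compound 2 to compound 3 (1.00 log units; beyond the scatter) is the only measured change. Compound 4 `Cc1ccc(C)c(/C=C(\C(=O)c2ccc(Cl)cc2)S(=O)(=O)c2ccc(Br)cc2)c1` differs from compound 3 by 4-bromophenyl in place of 4-chlorobenzyl on a sulfonyl sulfur. Among the compounds with values here, no measured step touches the sulfonyl group on its own; compound 1 carries the same 4-bromophenyl on its sulfonyl sulfur as compound 4 yet also differs from compound 3 elsewhere, and its value equals that of compound 3. Compound 4 is therefore expected to show no change at the digits printed from compound 3 to compound 4 (within the scatter), with an estimate of 10000 nM and a range from 3000 nM to 30000 nM.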

Compound 4, concentration for 50% growth inhibition: 1000 nM
Compound 4: the middle estimate sits 10-fold (1.00 log units) above what was measured; the whole stated range lies above it.
By their numbers in this assay, from the lowest: compounds 2 and 4 (each within the scatter of the next); then compounds 1 and 3 (each within the scatter of the next).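

In this assay, the group on the sulfonyl sulfur matters: with the 2,5-dimethylphenyl held fixed, 4-bromophenyl in place of 4-chlorobenzyl gives a 10-fold lower number from compound 3 to compound 4 (1.00 log units; beyond the scatter). The 4-bromophenyl does not set the value alone, since 2,5-dimethylphenyl in place of 3,5-dimethylphenyl gives a 10-fold lower number from compound 1 to compound 4 (1.00 log units; beyond the scatter). No evidence is available to account for either step.

On these data alone, whether the loss of the benzyl carbon or the swap of chlorine for bromine carries the first step remains open, as the two changes come together; 4-chlorophenyl or 4-bromobenzyl would separate them. As far as these compounds go, how an amine or a carboxylic acid would fare on the sulfonyl sulfur's ring also remains open.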